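From 2-bromophenoxy to 4-aminophenoxy

The source may report more compounds than this note shows. Statements on the series, on what has been measured and on what is new or still open speak of the compounds shown alone.

In a functional assay on SW480 cells (Homo sapiens) for antiproliferative activity, read by MTT assay, with a stated time of 48 h (on this read-out lower numbers stand for stronger inhibition and higher numbers for weaker inhibition), compound 1 `O=c1cc(-n2cc(CNc3ccccc3)nn2)c2cc(Br)ccc2o1` gives 18400 nM and compound 2 `O=c1cc(-n2cc(COc3ccccc3Br)nn2)c2cc(Br)ccc2o1` gives 20100 nM, so the two stand level. Compound 3 `Nc1ccc(OCc2cn(-c3cc(=O)oc4ccc(Br)cc34)nn2)cc1` is still unmeasured. It has 4-aminophenyl in place of 2-bromophenyl on an oxygen on a saturated carbon. Within the data shown here, the only measured step, with 2-bromophenoxy in place of anilino, is a 1.1-fold higher number from compound 1 to compound 2 (0.04 log units; within the scatter). That one step says nothing direct about 4-aminophenyl, so no shift beyond the scatter is expected in this assay, in either direction. The estimated change is a 1.2-fold lower number from compound 2 to compound 3 (0.07 log units; within the scatter). The estimate for compound 3 is 17000 nM, with an expected range of 7000 nM to 40000 nM.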

Compound 3, half-maximal inhibitory concentration: 2090 nM
For compound 3 the middle estimate is 8.1-fold (0.91 log units) above the measured one; measured number outside the range, below it.
By their numbers in this assay, from the lowest: compound 3; then compounds 1 and 2 (each within the scatter of the next).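

In this assay the group on this oxygen clearly matters: 4-aminophenyl in place of 2-bromophenyl brings a 9.6-fold lower number from compound 2 to compound 3 (0.98 log units; beyond the scatter) and so moves the number where the earlier change did not. 4-Aminophenoxy in place of anilino likewise brings an 8.8-fold lower number from compound 1 to compound 3 (0.94 log units; beyond the scatter) and marks this group as the one that stands apart among the three compounds. Nothing shown here explains the gain. Going by these compounds, it remains open whether the entering amine or the departing bromine carries the change. A plain phenoxy or a 4-hydroxyphenoxy group at this place would help separate the two.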